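Plasma stability of bicyclic diesters: varying the aryl ester

A few compounds are considered here, and "the series" means these few. Any claim that something is new, unique, unknown or untested is made for them only; others in the source may bear on it.

Measured so far:
compound 1 `CC(=O)Oc1ccccc1C(=O)O[C@H]1CO[C@H]2[C@@H]1OC[C@H]2OC(=O)c1ccc(-c2ccccc2)cc1` — in an ADME assay on a cell-free system (plasma, Homo sapiens) for metabolic stability, with Plasma (Rattus norvegicus) as the target, read by HPLC, at pH 7.4 (a higher number here means that the compound lasts longer, a lower number that the compound disappears faster), compound 1 gives > 0.333 h
compound 2 `CC(=O)Oc1ccccc1C(=O)O[C@H]1CO[C@H]2[C@@H]1OC[C@H]2OC(=O)c1ccncc1` — in this assay compound 2 gives 0.0617 h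

The value of compound 1 is a limit of the assay, not a number (the limit of > 0.333 h in this assay, at which 1 of the 2 values shown sits). Compound 2 thus holds the only numerical half-life in the set. Among the measured compounds shown here, the step of an at least 5.3-fold lower number from compound 1 to compound 2 (0.73 log units; beyond the scatter) is the sole measured comparison. Compound 3 `CC(=O)Oc1ccccc1C(=O)O[C@H]1CO[C@H]2[C@@H]1OC[C@H]2OC(=O)c1ccc(CO[N+](=O)[O-])cc1` carries 4-((nitrooxy)methyl)phenyl in place of pyridin-4-yl on a carbonyl carbon. This change returns to an aromatic ring of carbon only, as in compound 1, so a rise is expected, estimated as a 3.2-fold higher number from compound 2 to compound 3 (0.51 log units; beyond the scatter). For compound 3 the half-life is expected near 0.2 h, within 0.08 h to 0.5 h.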

Compound 3, half-life: 0.1 h
Compound 3: the middle estimate sits 2.0-fold (0.30 log units) above what was measured; measured number inside the range.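

Putting 4-((nitrooxy)methyl)phenyl in place of pyridin-4-yl on this carbonyl carbon leaves the half-life within the scatter (a 1.6-fold higher number from compound 2 to compound 3 (0.21 log units; within the scatter)), so an aromatic ring of carbon only does not by itself restore the longer half-life. The value of compound 1 is a limit of the assay, not a number: (the limit of > 0.333 h in this assay, at which 1 of the 3 values shown sits). Even against that limit, (nitrooxy)methyl in place of phenyl on an aromatic carbon gives a step beyond the scatter (an at least 3.3-fold lower number from compound 1 to compound 3 (0.52 log units; beyond the scatter)), which places the difference in that substituent.

Going by these compounds, the actual half-life of compound 1 remains open. So does the outcome with an amine, a carboxylic acid or a longer alkyl chain on that aromatic ring.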